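Swapping the Furan for a Substituted Benzyl Group

A few compounds are considered here, and "the series" means these few. Any claim that something is new, unique, unknown or untested is made for them only; others in the source may bear on it.

Three compounds sharing one core have been examined in a physicochemical assay for acid dissociation. Compound 1 `CCC(CC)c1ccc2c(NCCCNCc3ccco3)ccnc2c1` gives 9.47. Compound 2 `Clc1ccc(Oc2ccc3c(NCCCNCc4ccco4)ccnc3c2)cc1` gives 9.28, and compound 3 `c1ccc(-c2ccc3c(NCCCNCc4ccco4)ccnc3c2)cc1` gives 9.47. On the digits as reported compound 2 stands lowest of the three, but the gaps are small: a number 0.19 log units lower from compound 1 to compound 2 (within the scatter), no change at the digits printed from compound 1 to compound 3 (within the scatter), and a number 0.19 log units higher from compound 2 to compound 3 (within the scatter). All three differences fall within the scatter, so the three values cannot be told apart from one another.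

Compound 4 `COc1ccc(F)cc1CNCCCNc1ccnc2cc(Oc3ccc(Cl)cc3)ccc12` differs from compound 2 in one place: 5-fluoro-2-methoxyphenyl in place of furan-2-yl on a saturated chain carbon bound to an amine nitrogen. Among the measured compounds shown here, each of the measured steps altered the group on an aromatic carbon of the core, and none touched the chain carbon bound to the amine nitrogen, so no measured step bears directly on this change. What the three measured steps do show is that exchanging a distant aromatic group left this assay unmoved. Guided by that, the step from compound 2 to compound 4 is expected to be a number 0.12 log units higher from compound 2 to compound 4 (within the scatter). Compound 4 is therefore estimated at 9.4, within a range from 9 to 9.9.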

Compound 4, acid dissociation constant: 9.28
The estimate for compound 4 lay 0.12 log units above the measured number; measured number inside the range.
By their numbers in this assay, from the lowest: compounds 2, 4, 1 and 3 (each within the scatter of the next).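

In this assay the exchange at this position gives no change at the digits printed from compound 2 to compound 4 (within the scatter), so replacing furan-2-yl with 5-fluoro-2-methoxyphenyl on a saturated chain carbon bound to an amine nitrogen leaves no readable mark on the number. Among the compounds shown here, this is the only measured step at this place, since the earlier steps all altered a group on an aromatic carbon of the core, and it shows that a five-membered aromatic ring with 1 hetero atom and a larger six-membered aromatic ring of carbon only cannot be told apart here while the 4-chlorophenoxy group stays fixed. No measurement shown offers an explanation for this result.

As far as these compounds go, a single pair speaks to this change, so it remains open whether the same exchange would read the same way with pentan-3-yl or phenyl on the core. Also open, from the compounds shown here alone, is how this assay would respond to a group of a different kind at this place, such as a carboxylic acid or a longer saturated carbon chain in place of the aromatic ring.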